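Methyl on the fused ring: expectation for compound 4

A few compounds are considered here, and "the series" means these few. Any claim that something is new, unique, unknown or untested is made for them only; others in the source may bear on it.

Three compounds share one core. In a functional assay on A549 cells (Homo sapiens) for cytotoxicity, read by MTT assay, with a stated time of 72 h (a lower number here means a stronger inhibitor, a higher number a weaker inhibitor), compound 1 `Cc1cc(=O)n(-c2cccc(F)c2)nc1C(=O)Nc1ccc(Oc2ncnc3[nH]ccc23)cc1` gives 34800 nM. Compound 2 `Cc1cc(=O)n(-c2ccc(Br)cc2F)nc1C(=O)Nc1ccc(Oc2ncnc3[nH]ccc23)cc1` gives 3770 nM, the lowest of the three numbers, and compound 3 `Cc1cc(=O)n(-c2ccc(Br)cc2F)nc1C(=O)Nc1ccc(Oc2ncnc3[nH]ccc23)c(F)c1` gives 6120 nM. The step of a 9.2-fold lower number from compound 1 to compound 2 (0.97 log units; beyond the scatter) lies beyond the scatter, whereas a 1.6-fold higher number from compound 2 to compound 3 (0.21 log units; within the scatter) lies within it, so compound 2 stands clearly apart from compound 1 only and is not separable from compound 3.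

Compound 4 `Cc1cc(=O)n(-c2ccc(Br)cc2F)nc1C(=O)Nc1ccc(Oc2ncnc3c2ccn3C)cc1` differs from compound 2 by methyl in place of hydrogen on an aromatic nitrogen. Neither measured step touches that part of the molecule: the step from compound 1 to compound 2 and the step from compound 2 to compound 3 both alter other groups. Among the compounds with values here, no measured step therefore informs the direction of this change, and the working expectation is a step of about a 1.3-fold higher number from compound 2 to compound 4 (0.12 log units; within the scatter) from compound 2 to compound 4, that is, nothing beyond the scatter, with wide uncertainty in either direction. Compound 4 is estimated at 5000 nM, within a range of 1200 nM to 25000 nM.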

Compound 4, half-maximal inhibitory concentration: 47300 nM
Compound 4: middle estimate off by 9.5-fold (0.98 log units), on the low side, outside the stated range (above it).
By their numbers in this assay, from the lowest: compounds 2 and 3 (each within the scatter of the next); then compounds 1 and 4 (each within the scatter of the next).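

In this assay, within the data shown here, methyl in place of hydrogen on an aromatic nitrogen gives a 13-fold higher number from compound 2 to compound 4 (1.10 log units; beyond the scatter) and so provides the first measured reading at this position. The earlier steps shown here changed other groups and left this nitrogen open, whereas this large step beyond the scatter shows that the number in this assay is sensitive to a change of a single heavy atom here. No measurement shown explains this result.

As far as these compounds go, whether any substituent on this nitrogen raises the number to a similar extent remains open, as ethyl, a longer chain or a chain ending in an amine or a carboxylic acid would test that. Also open, from the compounds shown here alone, is whether the same step holds with the other groups found in compound 1 and compound 3.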